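A few compounds are considered here, and "the series" means these few. Any claim that something is new, unique, unknown or untested is made for them only; others in the source may bear on it.

Compound 2 `C=CCc1c(O)cc(O)c2c1OC(c1ccc(OC)cc1)CC2=O` gives 81% in a functional assay on aorta (Rattus norvegicus, strain Sprague-Dawley) for inhibition, with a stated time of 20 min (on this read-out higher numbers stand for larger maximal responses and lower numbers for smaller maximal responses), and compound 1 `C=CCc1c(O)cc(O)c2c1OC(c1cccc(Cl)c1)CC2=O` gives 76.7%; the two numbers sit close together, because a number 4.3 percentage points higher from compound 1 to compound 2 (within the scatter). Compound 3 `C=CCc1c(O)cc(O)c2c1OC(c1cccc(O)c1)CC2=O` has not yet been measured in this assay. It differs from compound 2 in one place: 3-hydroxyphenyl in place of 4-methoxyphenyl on a saturated ring carbon. Among the measured compounds shown here, the only measured step that bears on this change of the group on a saturated ring carbon stayed within the scatter, so no step beyond the scatter is expected here either. Compound 3 is therefore estimated at 78%, with a range from 64% to 92%, which means an expected step of a number 3 percentage points lower from compound 2 to compound 3 (within the scatter).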

Compound 3, largest response reached (Emax), in percent of the reference or control that the assay uses: 97.8%
The estimate for compound 3 lay 19.8 percentage points below the measured number; the measured number lies above the stated range.
By their numbers in this assay, from the lowest: compounds 1 and 2 (each within the scatter of the next); then compound 3.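

In this assay, among the compounds shown here, the group on this saturated ring carbon does affect the number: 3-hydroxyphenyl in place of 4-methoxyphenyl gives a number 16.8 percentage points higher from compound 2 to compound 3 (beyond the scatter), the first step here beyond the scatter. With the aromatic substituent's place kept, hydroxy in place of chloro gives a number 21.1 percentage points higher from compound 1 to compound 3 (beyond the scatter), so the change of that one substituent alone is enough for a clear step. No measurement available here explains why the hydroxy compound reaches the larger maximal response. Still open, going by these compounds, is whether an amine or a carboxylic acid on that same aromatic carbon would give a similar number. Also open, on these data alone, is whether hydroxy would keep this effect on a different carbon of the phenyl ring.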